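The source may report more compounds than this note shows. Statements on the series, on what has been measured and on what is new or still open speak of the compounds shown alone.

Two compounds share one core and are measured in an ADME assay on HEL cells (Homo sapiens) for cytotoxicity; a higher number here means that more compound is tolerated, a lower number that less compound is tolerated. Compound 1 `COc1cc(NC(C)CCCNC(=O)NCc2ccncc2)c2ncccc2c1` gives 100000 nM. Compound 2 `COc1cc(NC(C)CCCNC(=O)NC2CCCC2)c2ncccc2c1` gives 100000 nM. For the measured compounds named here, the one step between them, no change at the digits printed from compound 1 to compound 2 (within the scatter), replaces a (pyridin-4-yl)methyl group by a cyclopentyl group on the amide-type nitrogen, and it leaves the read-out where it was. On the numbers shown, compound 2 therefore stands level with compound 1 and with nothing else to compare against.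

Compound 3 `COc1cc(NC(C)CCCNC(=O)NCC2CCCCC2)c2ncccc2c1` is not yet measured. It differs from compound 2 by cyclohexylmethyl in place of cyclopentyl on an amide-type nitrogen. Going by the values given here, the only step on record, no change at the digits printed from compound 1 to compound 2 (within the scatter), also swaps one group for another on that same amide-type nitrogen and produces no change beyond the scatter, which is the sole bearing evidence here. Since that step was flat, a flat step is expected again for compound 3: the expected no change at the digits printed from compound 2 to compound 3 (within the scatter) is no change beyond the scatter. Compound 3 is estimated at 100000 nM in this assay, within a range from 50000 nM to 100000 nM.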

Compound 3, minimum cytotoxic concentration: 100000 nM
Compound 3: middle estimate and measured number agree at the digits printed; the measured number falls inside the stated range.
By their numbers in this assay, from the lowest: compounds 1, 2 and 3 (each within the scatter of the next).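

Swapping cyclopentyl (5 heavy atoms, a five-membered ring) for cyclohexylmethyl (7 heavy atoms, a six-membered ring) on the amide-type nitrogen gives no change at the digits printed from compound 2 to compound 3 (within the scatter) in this assay, so this position has now taken a larger carbon-only group without any shift in the tolerated concentration. The second new comparison isolates the ring itself, with cyclohexyl in place of pyridin-4-yl on the saturated chain carbon bound to that nitrogen, and it gives no change at the digits printed from compound 1 to compound 3 (within the scatter), so for these compounds the read-out is the same with either ring on that carbon. No measurement here explains why the read-out stays the same across these three groups.

All three groups carry no net charge, so a carboxylic acid or a primary amine on this nitrogen remains an open case, as does a longer chain such as cyclohexylpropyl. These compounds also share one core and one chain, so they say nothing about how the read-out would respond to a change elsewhere, such as replacing the methoxy group.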